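The source may report more compounds than this note shows. Statements on the series, on what has been measured and on what is new or still open speak of the compounds shown alone.

Of the compounds shown here, three have so far been measured in a functional assay on A549 cells (Homo sapiens) for antiproliferative activity, read by MTT assay, with a stated time of 72 h; a higher number here means a weaker inhibitor, a lower number a stronger inhibitor.

Compound 1, `COc1cc2ncnc(Nc3ccc(Cl)cc3)c2cc1OCCCCC(=O)Nc1ccc(S(N)(=O)=O)cc1`, gives > 40000 nM; this is a limit of the assay, not a number.
Compound 2, `COc1ccccc1Nc1ncnc2cc(OC)c(OCCCCC(=O)Nc3ccc(S(N)(=O)=O)cc3)cc12`, gives 24100 nM.
Compound 3, `NS(=O)(=O)c1ccc(NC(=S)Nc2ccc3ncnc(Nc4ccc(Cl)c(C(F)(F)F)c4)c3c2)cc1`, gives 4500 nM.

Compound 3 holds the lowest of the two numbers shown; the nearest, compound 2, stands clearly higher, beyond the usual scatter of this assay, while compound 1 contributes only a limit.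

Compound 4, `NS(=O)(=O)c1ccc(NC(=S)Nc2ccc3ncnc(Nc4cccc(F)c4)c3c2)cc1`, is yet to be measured. It differs from compound 3 in one place: 3-fluorophenyl in place of 4-chloro-3-(trifluoromethyl)phenyl on a nitrogen on an aromatic ring.

Among the measured compounds shown here, only one measured step is of the same kind, an exchange of the aryl group on that nitrogen: an at least 1.6-fold lower number from compound 1 to compound 2 (0.22 log units; that floor lies within the scatter). Its size is uncertain, since compound 1 sits at the limit described by the limit of > 40000 nM in this assay, at which 1 of the 3 values shown sits, and the floor of that step lies within the scatter. That step shows that swapping the aryl group on this nitrogen can shift the number, but it does not fix how far or in which direction for the present change. Compound 4 is therefore expected to remain in the same broad region as compound 3, with a modest move toward a higher number, a 1.8-fold higher number from compound 3 to compound 4 (0.25 log units; within the scatter), anticipated. The estimate for compound 4 in this assay is 8000 nM, with a likely range from 2500 nM to 25000 nM.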

Compound 4, half-maximal inhibitory concentration: 25900 nM
The estimate for compound 4 lay 3.2-fold (0.51 log units) below the measured number; the measured number lies above the stated range.
By their numbers in this assay, from the lowest: compound 3; then compounds 2 and 4 (each within the scatter of the next). At a limit, above all of these: compound 1.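

In this assay, with the rest of the molecule unchanged, 3-fluorophenyl in place of 4-chloro-3-(trifluoromethyl)phenyl on a nitrogen on an aromatic ring gives a 5.8-fold higher number from compound 3 to compound 4 (0.76 log units; beyond the scatter). Among the compounds shown here, this is the first exchange of the group on this nitrogen whose full size can be read, and it shows that the group matters on the core of compound 3: the step goes beyond the scatter, and the number moves upward when the chlorine and the trifluoromethyl leave and a single fluorine enters. The earlier exchange of the group on this nitrogen, on a different core, gave no full size to set against this step because compound 1 stands at a limit and not at a number: the limit of > 40000 nM in this assay, at which 1 of the 4 values shown sits.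

On these data alone, whether the chlorine or the trifluoromethyl accounts for the step stays open, as does how 4-chlorophenyl or 3-(trifluoromethyl)phenyl alone would read on the core of compound 3. Also open, as far as these compounds go, is how a nitrile or an amine on this phenyl ring would read, and whether the same exchange would give a step of similar size on the core of compound 1.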